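This account rests on a few compounds, and the source may have more. Where it says the series, first, only, none or still open, it means among the compounds named here.

Compound 3 `c1ccc2c(c1)CCN(c1ccnc(Nc3ccc(Oc4ncnc5ccsc45)cc3)n1)C2` carries a 1,2,3,4-tetrahydroisoquinolin-2-yl group on the shared core. In a functional assay on A549 cells (Homo sapiens) for inhibition, read by MTT assay, with a stated time of 72 h, tested at 20 uM (on this read-out higher numbers stand for more inhibition at the one concentration tested (going by the name of the read-out) and lower numbers for less inhibition), compound 3 gives 54.9%, which is the lowest of the three numbers measured, though its gaps to the other two compounds both fall within the scatter. Compound 1 `c1cc(N2CCCCC2)nc(Nc2ccc(Oc3ncnc4sccc34)cc2)n1` gives 64.8% in this assay, and compound 2 `CNC(=O)c1cc(Oc2ccc(Nc3nccc(N4CCCCC4)n3)cc2)ccn1` gives 63.4%. Going by the values given here, the one step measured between neighbours, a number 1.4 percentage points lower from compound 1 to compound 2 (within the scatter), concerns the group on the aromatic oxygen and not the amine on the core, so it does not bear directly on the change now considered. Compound 4 `c1cc(N2CCCCC2)nc(Nc2ccc(Oc3ncnc4ccsc34)cc2)n1` differs from compound 3 by piperidin-1-yl in place of 1,2,3,4-tetrahydroisoquinolin-2-yl on an aromatic carbon. Among the compounds with values here, no measured pair isolates this exchange; compound 1 also bears piperidin-1-yl, and its value and that of compound 3 lie within the scatter of one another. Compound 4 is therefore expected to show a step of a number 5.1 percentage points higher from compound 3 to compound 4 (within the scatter), not beyond the scatter. The estimated value of compound 4 in this assay is 60%, between 47% and 72%.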

Compound 4, a percentage reported as inhibition, at one concentration (the size of the read-out at that concentration, not a potency): 59.9%
Compound 4: middle estimate off by 0.1 percentage points, on the high side; measured number inside the range.
By their numbers in this assay, from the lowest: compounds 3, 4, 2 and 1 (each within the scatter of the next).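

In this assay, the exchange on this aromatic carbon now has a direct measure, a number 5 percentage points higher from compound 3 to compound 4 (within the scatter), so going from 1,2,3,4-tetrahydroisoquinolin-2-yl to piperidin-1-yl, which leaves out the six-membered aromatic ring of carbon only, does not move the number beyond the scatter. With piperidin-1-yl held in place, changes to the group on the aromatic oxygen also stay within the scatter, giving a number 3.5 percentage points lower from compound 2 to compound 4 (within the scatter) and a number 4.9 percentage points lower from compound 1 to compound 4 (within the scatter), the latter between two groups of the same printed atom make-up. No available evidence bears on these results. It remains open whether a morpholin-4-yl or a dimethylamino group on this aromatic carbon would stay within the scatter of these compounds. Each number is also the size of the read-out at one concentration, so the potency of these compounds remains open.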